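This account rests on a few compounds, and the source may have more. Where it says the series, first, only, none or still open, it means among the compounds named here.

Working notes on the series.

Compound 3 `O=C1N(Cc2ccccc2Cl)c2cccn2S(=O)(=O)N1Cc1cccc(F)c1` is the reference point. In an ADME assay on MT4 cells (Homo sapiens) for cytotoxicity, read by MTT assay, with a stated time of 5 days (a lower number here means that less compound is tolerated, a higher number that more compound is tolerated), compound 3 gives 231000 nM. Compound 2 `O=C1N(Cc2ccccc2Br)c2cccn2S(=O)(=O)N1Cc1ccccc1` gives 226000 nM in this assay, and the two values lie within the scatter of each other, so no order can be read between them. Compound 1 `O=C1N(Cc2ccccc2Cl)c2cccn2S(=O)(=O)N1Cc1cccc(Br)c1` gives only a limit, > 260000 nM, in this assay. Compound 3 thus stands with the higher of the two actual numbers, its nearest neighbour compound 2 indistinguishable from it, and the third value a limit. For the measured compounds named here, the one measured step, an at least 1.1-fold lower number from compound 1 to compound 3 (0.05 log units; that floor lies within the scatter), is fluoro in place of bromo on an aromatic carbon and sits within the scatter.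

Compound 4 `O=C1N(Cc2ccccc2)c2cccn2S(=O)(=O)N1Cc1cccc(F)c1` differs from compound 3 by hydrogen in place of chloro on an aromatic carbon. Going by the values given here, no measured step matches this change; the only step available, from compound 1 to compound 3, concerns a different halogen swap and was itself within the scatter, and all values cluster near the limit noted in the limit of > 260000 nM in this assay, at which 1 of the 3 values shown sits. The step of a 1.0-fold lower number from compound 3 to compound 4 (0.00 log units; within the scatter) is therefore expected to stay within the scatter. Compound 4 is estimated at 230000 nM, with a range from 120000 nM to 480000 nM.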

Compound 4, half-maximal cytotoxic concentration: > 288000 nM
Compound 4: only a limit was reported (the forecaster's own chance of this, stated with the estimate: 30%); at least 1.2-fold (0.09 log units) between middle value and limit.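

For the compounds shown here, this is the first step at this place, on an aromatic carbon ortho to a large group, where 2-chlorobenzyl becomes benzyl; the earlier step concerned only a halogen swap on the other benzyl group. In this assay, hydrogen in place of chloro gives an at least 1.2-fold higher number from compound 3 to compound 4 (0.09 log units; that floor lies within the scatter). The value for compound 4 is a limit, so the step sets only a floor, and the data show no lower number with hydrogen here, while the true size of the step cannot be read: the limit of > 288000 nM in this assay, at which 1 of the 4 values shown sits.

All the compounds shown carry only hydrogen or a halogen on these benzyl groups, so the outcome with an amine, a carboxylic acid or a longer chain at this place stays open. On these data alone, compound 1 and compound 4 both give limits, and their true values also stay open.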